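The source may report more compounds than this note shows. Statements on the series, on what has been measured and on what is new or still open speak of the compounds shown alone.

Compound 1 `COc1ccc(C(=O)/C=C/c2ccccc2)c2c1C=CC(C)(C)O2`: > 10000 nM
Compound 2 `COc1ccc(C(=O)/C=C/c2ccc(Cl)cc2)c2c1C=CC(C)(C)O2`: > 10000 nM

In a functional assay on HCT-116 cells (Homo sapiens) for antiproliferative activity, read by MTT assay, with a stated time of 24 h (a lower number here means a stronger inhibitor, a higher number a weaker inhibitor), compound 2 gives > 10000 nM, which is a limit and not a number. Compound 1 gives > 10000 nM, also a limit. Both thus share (the limit of > 10000 nM in this assay, at which 2 of the 2 values shown sit).

Compound 3 `COc1ccc(C(=O)/C=C/c2ccc(Cl)c(Cl)c2)c2c1C=CC(C)(C)O2` takes a second chloro, going from 4-chlorophenyl to 3,4-dichlorophenyl: chloro in place of hydrogen on an aromatic carbon. Among the compounds with values here, the only measured step of this kind is a step that the two limits leave unreadable from compound 1 to compound 2, so it offers no size or direction to carry over, and no shift beyond the scatter is expected in this assay. The estimated step is a step that the limit leaves unreadable from compound 2 to compound 3. Compound 3 is expected at 12000 nM, with an estimated range from 4000 nM to 40000 nM.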

Compound 3, half-maximal inhibitory concentration: 9440 nM
Compound 3: the middle estimate sits 1.3-fold (0.10 log units) above what was measured; the range from low to high includes it.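

Within the data shown here, a second chloro, ortho to a chloro group, gives the first reading in this assay that is a number and not a limit, with an at least 1.0-fold lower number from compound 2 to compound 3 (0.02 log units; that floor lies within the scatter). Measured against the unsubstituted phenyl, the change gives an at least 1.0-fold lower number from compound 1 to compound 3 (0.02 log units; that floor lies within the scatter). Neither floor goes beyond the scatter, and the true size of either step stays unread because both starting values are limits: the limit of > 10000 nM in this assay, at which 2 of the 3 values shown sit.

The compounds shown leave open whether a chloro at this position gives a number without the 4-chloro. They also leave open whether a methoxy or an amine there would move the value beyond the scatter.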